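The compounds below may be only part of what the source reports. "The series", "measured", "known", "first", "only" and "open" are said of these compounds alone.

Measured compounds in a functional assay on LS174T cells (Homo sapiens) for inhibition, with a stated time of 4 days, tested at 1 uM; a higher number here means a stronger effect of the compound at the concentration tested, a lower number a weaker effect:
compound 1 `Fc1cccc(F)c1C#Cc1ccc(-n2cccc2)nc1`: 80.5%
compound 2 `Fc1cccc(F)c1C#Cc1ccc2[nH]ccc2c1`: 52.9%
compound 3 `Fc1cccc(F)c1C#Cc1ccc2[nH]ncc2c1`: 17.6%

Compound 3 stands lowest of the three numbers in this assay. Its nearest neighbour is compound 2, whose value is higher by a gap beyond the scatter; the furthest is compound 1, whose value is higher by a still larger gap, also beyond the scatter. Within the data shown here, no pair of measured compounds differs in a single place, so no measured step is available as a guide.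

Compound 4 `Cn1ncc2cc(C#Cc3c(F)cccc3F)ccc21` is not yet measured in this assay. Relative to compound 3 it carries methyl in place of hydrogen on an aromatic nitrogen; nothing else changes.

Among the measured compounds shown here, with no comparable step among the measured compounds, the size of this step is uncertain. The expectation is a modest rise from compound 3, of the order of a number 12.4 percentage points higher from compound 3 to compound 4 (beyond the scatter), possibly no larger than the scatter. Compound 4 is accordingly estimated at 30% in this assay, with a range from 5% to 60%; a value within the scatter of compound 3 would not be surprising.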

Compound 4, a percentage reported as inhibition, at one concentration (the size of the read-out at that concentration, not a potency): 58.4%
Compound 4: the middle estimate sits 28.4 percentage points below what was measured, and the stated range covers the measured number.
By their numbers in this assay, from the lowest: compound 3; then compounds 2 and 4 (each within the scatter of the next); then compound 1.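

In this assay, among these compounds, the aromatic nitrogen of the five-membered ring proves responsive to substitution: methyl in place of hydrogen gives a number 40.8 percentage points higher from compound 3 to compound 4 (beyond the scatter) and provides the first single-place comparison. The hydrogen on this nitrogen is therefore not required for the effect at the concentration tested, and the low value of compound 3 does not carry over to its methylated counterpart. No measurement available here bears on the reason for this step.

A single methyl leaves the reach of this position undefined: whether an ethyl, a longer chain, or a chain ending in an amine or a carboxylic acid would keep, raise or lower the effect cannot be told. Also open, on these data alone, is whether methyl on the ring nitrogen of compound 2 would give a step of similar size.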